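The source may hold more compounds than are shown below. What is called first, only, known or untested is meant among the compounds shown, and "the series" means these compounds.

Measured so far:
compound 1 `COc1ccc(F)c([C@H]2CC[C@H](COc3cccc([C@H](C4CC4)[C@@H](C)C(=O)O)c3)CC2)c1` gives 4.9 nM in a functional assay on HEK293 cells for agonist activity at Free fatty acid receptor 1 (Rattus norvegicus), read by FLIPR and calcium flux; on this read-out lower numbers stand for an effect already at smaller amounts and higher numbers for an effect only at larger amounts of compound
compound 2 `COc1ccc(F)c([C@H]2CC[C@H](COc3cccc([C@H](C4CC4)C(C)(C)C(=O)O)c3)CC2)c1` gives 0.31 nM

Going by the values given here, compound 2 stands lowest of the two numbers; the gap to its only neighbour is a 16-fold lower number from compound 1 to compound 2 (1.20 log units; beyond the scatter). Compound 3 `COc1ccc(F)c([C@H]2CC[C@H](COc3cccc([C@H](C4CC4)C(F)(F)C(=O)O)c3)CC2)c1` differs from compound 2 by carboxy(difluoro)methyl in place of 1-carboxy-1-methylethyl on a saturated chain carbon bound to an aromatic carbon and a saturated ring carbon. Among the compounds with values here, no measured step matches this exchange; the single step in hand, a 16-fold lower number from compound 1 to compound 2 (1.20 log units; beyond the scatter), concerns a methyl entering in place of hydrogen, not fluorine in place of methyl, so it bears only loosely. A moderate rise is expected for compound 3, a 6.5-fold higher number from compound 2 to compound 3 (0.81 log units; beyond the scatter). Compound 3 is estimated at 2 nM, with a range of 0.4 nM to 10 nM.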

Compound 3, half-maximal effective concentration: 34 nM
For compound 3 the middle estimate is 17-fold (1.23 log units) below the measured one, outside the stated range (above it).
By their numbers in this assay, from the lowest: compound 2; then compound 1; then compound 3.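

In this assay, on the saturated chain carbon bound to an aromatic carbon and a saturated ring carbon, the gain seen with 1-carboxy-1-methylethyl does not carry over to carboxy(difluoro)methyl, with a 110-fold higher number from compound 2 to compound 3 (2.04 log units; beyond the scatter). The same group also compares poorly with 1-carboxyethyl, with a 6.9-fold higher number from compound 1 to compound 3 (0.84 log units; beyond the scatter), so fluorine does not stand in for methyl here and full substitution of this carbon does not suffice on its own. No available evidence bears on this result. Still open, going by these compounds, is whether a 1-carboxy-1-fluoroethyl or 1-carboxycyclobutyl group at this place would stay near compound 2 or fall towards compound 3.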